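A Smaller Aryl Group Replaces a Methoxynaphthyl Ring

The compounds below may be only part of what the source reports. "The series", "measured", "known", "first", "only" and "open" are said of these compounds alone.

Two compounds from this series share the same core and differ only in the aryl group on a saturated ring carbon. Compound 1 `COc1cc(N2C(N)=C(C#N)C(c3ccc([N+](=O)[O-])cc3)C3=C2CC(C)(C)CC3=O)cc(OC)c1OC` carries a 4-nitrophenyl group there, and in a functional assay on Ehrlich cells (Mus musculus) for cytotoxicity (a higher number here means a weaker inhibitor, a lower number a stronger inhibitor), compound 1 gives 25000 nM, a weak result. Compound 2 `COc1cc(N2C(N)=C(C#N)C(c3ccc(OC)c4ccccc34)C3=C2CC(C)(C)CC3=O)cc(OC)c1OC` carries a 4-methoxynaphthalen-1-yl group instead; in this assay compound 2 is recorded as "not active" (no number reported), so no number stands for it and it cannot be placed on the scale. Compound 3 `COc1cc(N2C(N)=C(C#N)C(c3ccc(C)cc3)C3=C2CC(C)(C)CC3=O)cc(OC)c1OC` is the next member: 4-methylphenyl in place of 4-methoxynaphthalen-1-yl on a saturated ring carbon. For the measured compounds named here, no measured pair tells how this change plays out, so the direction and size of the step are open. Given that compound 1 shows only weak activity at 25000 nM, compound 3 is expected to stay in the weak range, with an estimated value of 30000 nM, between 8000 nM and 120000 nM.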

Compound 3, half-maximal inhibitory concentration: 52900 nM
Compound 3: the middle estimate sits 1.8-fold (0.25 log units) below what was measured; the measured number falls inside the stated range.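

In this assay compound 3 has a number where compound 2 has none, so 4-methylphenyl on this saturated ring carbon can be placed on the scale, while the step from 4-methoxynaphthalen-1-yl cannot be read. The readable comparison is methyl in place of nitro on the phenyl ring, which gives a 2.1-fold higher number from compound 1 to compound 3 (0.33 log units; beyond the scatter) and shows that this small substituent change moves the result by a modest but real amount, with both compounds remaining weak. Nothing measured here explains that shift.

For the compounds shown here, with only two numbers, no trend across substituents can be drawn. Open questions are how an amine, a carboxylic acid or a longer alkyl chain on the phenyl ring would behave, and whether any such group would give a much lower number.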